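Demethylation of a phenol ether in a urea-linked pyrazole series

The compounds below may be only part of what the source reports. "The series", "measured", "known", "first", "only" and "open" are said of these compounds alone.

The series is followed in a functional assay on NCI-H226 cells (Homo sapiens) for inhibition, read by sulforhodamine B assay, with a stated time of 48 h; on this read-out higher numbers stand for weaker inhibition of growth and lower numbers for stronger inhibition of growth. Compound 1 `O=C(Nc1cccc(-n2cc(-c3ccncc3)c(-c3ccc(Cl)c(O)c3)n2)c1)Nc1cccc(C(F)(F)F)c1` gives only a limit there, > 32500 nM, a sign that the assay reached its ceiling without a number being reached. Compound 2 `COc1cc(-c2nn(-c3cccc(NC(=O)Nc4cc(C(F)(F)F)cc(C(F)(F)F)c4)c3)cc2-c2ccncc2)ccc1Cl` is the one member with a measured value, 21800 nM, and so it stands alone as the sole number among the two results shown. The other result, that of compound 1, is a limit (the limit of > 32500 nM in this assay, at which 1 of the 2 values shown sits). Compound 3 `O=C(Nc1cccc(-n2cc(-c3ccncc3)c(-c3ccc(Cl)c(O)c3)n2)c1)Nc1cc(C(F)(F)F)cc(C(F)(F)F)c1` has not yet been measured; it differs from compound 2 by hydrogen in place of methyl on an oxygen on an aromatic ring. For the measured compounds named here, with no measured step between two compounds that differ in one place, the size of this change cannot be read from the data, and the change is expected to fall within the usual scatter or somewhat towards weaker growth inhibition, as the step of a 1.3-fold higher number from compound 2 to compound 3 (0.11 log units; within the scatter) sets out. Compound 3 is therefore estimated at 28000 nM, with a range from 12000 nM to 65000 nM, and with a fair chance that only a limit is reported.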

Compound 3, concentration for total growth inhibition: 6120 nM
The estimate for compound 3 lay 4.6-fold (0.66 log units) above the measured number; measured number below the stated range.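

In this assay, the change from methoxy to hydroxy, hydrogen in place of methyl on an oxygen on an aromatic ring, gives a 3.6-fold lower number from compound 2 to compound 3 (0.55 log units; beyond the scatter). For the compounds shown here, this is the first measured sign that the group on this oxygen affects growth inhibition, and in this one pair the hydroxy form is the stronger of the two. The hydroxy group does not settle the matter alone, since with it held in place, trifluoromethyl in place of hydrogen on an aromatic carbon gives an at least 5.3-fold lower number from compound 1 to compound 3 (0.72 log units; beyond the scatter), a step that has no exact size, for the figure of compound 1 is a limit and not a number: the limit of > 32500 nM in this assay, at which 1 of the 3 values shown sits.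

The compounds shown leave open whether the change from methoxy to hydroxy would have a similar size in the setting of compound 1, and they do not say why either step takes the size it does. From the compounds shown here alone, it also remains open how growth inhibition would respond on this oxygen-bearing position to an amine, a carboxylic acid or a longer chain such as ethoxy.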